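The source may report more compounds than this note shows. Statements on the series, on what has been measured and on what is new or still open speak of the compounds shown alone.

Measured so far:
- compound 1, `COc1cc(Cc2cnc(/N=C3\C(=O)N(CN(Cc4ccccc4)Cc4ccccc4)c4ccc(Cl)cc43)nc2N)cc(OC)c1OC`: 44.1 ug/mL
- compound 2, `CCCCN(CCCC)CN1C(=O)/C(=N\c2ncc(Cc3cc(OC)c(OC)c(OC)c3)c(N)n2)c2cc(Cl)ccc21`: 62.6 ug/mL

The read-out is an ADME assay on MT4 cells (Homo sapiens) for cytotoxicity, read by MTT assay, with a stated time of 5 days; a higher number here means that more compound is tolerated, a lower number that less compound is tolerated. Of the two numbers, compound 2 holds the higher, and the nearest is compound 1 at 44.1 ug/mL; the gap between the two is within the scatter, so the two compounds are taken as tolerated alike.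

Compound 3 is `COc1cc(Cc2cnc(/N=C3\C(=O)N(CN4CCN(c5ccccn5)CC4)c4ccc(Cl)cc43)nc2N)cc(OC)c1OC`, not yet measured in this assay. It differs from compound 2 in one place: 4-(pyridin-2-yl)piperazin-1-yl in place of dibutylamino on a saturated chain carbon bound to an amide-type nitrogen in a ring. Going by the values given here, no step between measured compounds exists for this change, so nothing says how the half-maximal cytotoxic concentration responds to it. The two measured compounds differ at the same saturated chain carbon and still fall within the scatter of each other, which is the only hint available, and it points to no step beyond the scatter.

The expectation is therefore a step of a 1.3-fold lower number from compound 2 to compound 3 (0.10 log units; within the scatter), in no firm direction. Compound 3 is estimated at 50 ug/mL, with a range from 20 ug/mL to 120 ug/mL.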

Compound 3, half-maximal cytotoxic concentration: 39.2 ug/mL
Estimate against measurement, compound 3: 1.3-fold (0.11 log units) above, within the range that was stated.
By their numbers in this assay, from the lowest: compounds 3, 1 and 2 (each within the scatter of the next).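

Under this assay the exchange of dibutylamino for 4-(pyridin-2-yl)piperazin-1-yl gives a 1.6-fold lower number from compound 2 to compound 3 (0.20 log units; within the scatter) and is the first step read on a saturated chain carbon bound to an amide-type nitrogen in a ring. This position therefore accepts a group of 12 heavy atoms, with one six-membered non-aromatic ring and one six-membered aromatic ring, in place of a group of 9 heavy atoms with no ring, and the step stays within the scatter. The added ring content and the 3 hydrogen-bond acceptors in place of 1 thus come with no step beyond the scatter in this read-out, and no measurement on hand accounts for that.

The compounds shown leave open whether a different group on the same chain carbon, such as dimethylamino, morpholin-4-yl or a carboxylic acid on a longer chain, would give a step beyond the scatter. They also leave open whether 4-(pyridin-2-yl)piperazin-1-yl would give a similar step on a core carrying a group other than the chlorine shared by these compounds.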